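Swapping the Aryl Group on the Aromatic Nitrogen

The source may hold more compounds than are shown below. What is called first, only, known or untested is meant among the compounds shown, and "the series" means these compounds.

Compound 2 `CNC(=O)c1cc(Oc2ccc(NC(=O)c3nn(-c4ccc(Br)cc4F)c(=O)cc3C)cc2F)ccn1` gives 9360 nM in a functional assay on MCF7 cells (Homo sapiens) for cytotoxicity, read by MTT assay, with a stated time of 72 h (on this read-out higher numbers stand for weaker inhibition and lower numbers for stronger inhibition), the lower of the two numbers measured; compound 1 `CNC(=O)c1cc(Oc2ccc(NC(=O)c3nn(-c4ccccc4C(F)(F)F)c(=O)cc3C)cc2F)ccn1` gives 35700 nM. Compound 3 `CNC(=O)c1cc(Oc2ccc(NC(=O)c3nn(-c4ccccc4OC(F)(F)F)c(=O)cc3C)cc2F)ccn1` carries 2-(trifluoromethoxy)phenyl in place of 4-bromo-2-fluorophenyl on an aromatic nitrogen. Going by the values given here, the one step that bears on this change is a 3.8-fold lower number from compound 1 to compound 2 (0.58 log units; beyond the scatter), where 2-(trifluoromethyl)phenyl gave way to 4-bromo-2-fluorophenyl. Since 2-(trifluoromethoxy)phenyl resembles the group of compound 1 more than that of compound 2, that step is expected to run partly in reverse. Compound 3 is therefore estimated at 22000 nM, within 7000 nM to 70000 nM, an expected step of a 2.4-fold higher number from compound 2 to compound 3 (0.37 log units; beyond the scatter).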

Compound 3, half-maximal inhibitory concentration: > 40000 nM
Compound 3 ended at the assay's limit (the forecaster's own chance of this, stated with the estimate: 10%); at least 1.8-fold (0.25 log units) between middle value and limit.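

The change brings an at least 4.2-fold higher number from compound 2 to compound 3 (0.63 log units; beyond the scatter), so at this position 4-bromo-2-fluorophenyl keeps the lowest number of the three aryl groups. Trifluoromethoxy in place of trifluoromethyl brings an at least 1.1-fold higher number from compound 1 to compound 3 (0.04 log units; that floor lies within the scatter), so these two groups cannot be ordered here. The entry for compound 3 is a limit and not a number: the limit of > 40000 nM in this assay, at which 1 of the 3 values shown sits.

The compounds shown leave open how much of the difference belongs to the bromine and how much to the fluorine of compound 2. They also leave open how a non-aromatic group, such as a morpholine or a short chain carrying an amine, would read on this nitrogen.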